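The source may report more compounds than this note shows. Statements on the series, on what has been measured and on what is new or still open speak of the compounds shown alone.

In a functional assay on NCI-H460 cells (Homo sapiens) for inhibition, read by sulforhodamine B assay, with a stated time of 48 h (on this read-out lower numbers stand for stronger inhibition of growth and higher numbers for weaker inhibition of growth), three compounds sharing one core have been measured. Compound 1 (`Brc1ccc(Cn2cc(CCCOc3cccc4cccnc34)nn2)cc1`) gives 11.7 ug/mL, compound 2 (`FC(F)(F)Oc1ccc(Cn2cc(CCCOc3cccc4cccnc34)nn2)cc1`) gives 10.4 ug/mL, and compound 3 (`Fc1ccc(Cn2cc(CCCOc3cccc4cccnc34)nn2)cc1F`) gives 23.7 ug/mL. Compound 3 has the highest number of the three, so it is the weakest growth inhibitor so far.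

Compound 4 (`c1cncc(CCCn2cc(CCCOc3cccc4cccnc34)nn2)c1`) is the next to be tested, and it differs from compound 3 as follows: 2-(pyridin-3-yl)ethyl in place of 3,4-difluorophenyl on a saturated chain carbon bound to an aromatic nitrogen. Put simply, 2-(pyridin-3-yl)ethyl stands in place of 3,4-difluorophenyl on a saturated chain carbon bound to an aromatic nitrogen.

Within the data shown here, two measured steps bear on this part of the molecule: a 1.1-fold lower number from compound 1 to compound 2 (0.05 log units; within the scatter), and a 2.0-fold higher number from compound 1 to compound 3 (0.31 log units; beyond the scatter). Both are small, but neither brings in 2-(pyridin-3-yl)ethyl, so they are only a loose guide. No step beyond the scatter is therefore expected in this assay. The expected result is a 1.1-fold higher number from compound 3 to compound 4 (0.04 log units; within the scatter). For compound 4 the estimated value is 26 ug/mL, within an expected range of 11 ug/mL to 60 ug/mL.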

Compound 4, concentration for 50% growth inhibition: 44.3 ug/mL
Compound 4: the middle estimate sits 1.7-fold (0.23 log units) below what was measured; the measured number falls inside the stated range.
By their numbers in this assay, from the lowest: compounds 2 and 1 (each within the scatter of the next); then compounds 3 and 4 (each within the scatter of the next).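

In this assay, 3-(pyridin-3-yl)propyl in place of 3,4-difluorobenzyl gives a 1.9-fold higher number from compound 3 to compound 4 (0.27 log units; within the scatter), so at this place a ring with a hetero atom, held on a longer chain, reads the same as the difluorinated ring within the usual scatter. The same group in place of 4-bromophenyl gives a 3.8-fold higher number from compound 1 to compound 4 (0.58 log units; beyond the scatter), a modest step, so the outcome for this group depends on which earlier compound serves as the reference. No measurement at hand explains either step.

Ring and chain length change together here, so their separate contributions cannot be told apart; a 3-phenylpropyl group or a pyridin-3-ylmethyl group at this place would pull them apart. Going by these compounds, how a simple amine or a carboxylic acid at the end of such a chain would read also remains open.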